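This account rests on a few compounds, and the source may have more. Where it says the series, first, only, none or still open, it means among the compounds named here.

In a functional assay on DU-145 cells (Homo sapiens) for inhibition, read by trypan blue exclusion, with a stated time of 72 h (a lower number here means a stronger inhibitor, a higher number a weaker inhibitor), compound 1 `Cn1c(=O)c(S(=O)(=O)c2ccccc2)cc2cnc(Nc3ccc4ncccc4c3)nc21` gives 50000 nM, while compound 2 `Cc1ccc(S(=O)(=O)c2cc3cnc(Nc4cnc5c(c4)CC(=O)N5)nc3n(C)c2=O)cc1` gives 15000 nM. Compound 2 therefore has the lower of the two numbers, by a gap beyond the usual scatter. Compound 3 `Cc1ccc(S(=O)(=O)c2cc3cnc(Nc4cccc5cccnc45)nc3n(C)c2=O)cc1` keeps the core of compound 2 and changes one group, on a nitrogen on an aromatic ring: a group of 10 heavy atoms (9 carbon, 1 nitrogen; one six-membered aromatic ring of carbon only, one six-membered aromatic ring with 1 hetero atom) in place of a group of 10 heavy atoms (7 carbon, 2 nitrogen, 1 oxygen; one five-membered non-aromatic ring with 1 hetero atom, one six-membered aromatic ring with 1 hetero atom), on a nitrogen on an aromatic ring. Among the measured compounds shown here, no measured pair shows a step of this kind, so only a small move toward a higher, weaker number is expected, perhaps none beyond the scatter. For compound 3, the estimated value is 20000 nM, with an expected range of 6000 nM to 50000 nM. This estimate means an expected 1.3-fold higher number from compound 2 to compound 3 (0.12 log units; within the scatter).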

Compound 3, half-maximal inhibitory concentration: 10000 nM
Compound 3: the middle estimate sits 2.0-fold (0.30 log units) above what was measured; the measured number falls inside the stated range.
By their numbers in this assay, from the lowest: compounds 3 and 2 (each within the scatter of the next); then compound 1.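

The step at this nitrogen on an aromatic ring in this assay (a 1.5-fold lower number from compound 2 to compound 3 (0.18 log units; within the scatter)) lies within the scatter. Quinolin-8-yl, with 0 hydrogen-bond donors, thus takes the place of a group with a five-membered non-aromatic ring and 1 hydrogen-bond donor without a change that can be told from scatter. No outside measurement bears on this result. On these data alone, whether a plain phenyl or a phenyl carrying a morpholine on this nitrogen would give a number beyond the scatter remains open.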